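The source may report more compounds than this note shows. Statements on the series, on what has been measured and on what is new or still open speak of the compounds shown alone.

Within the data shown here, in a functional assay on HCT-116 cells (Homo sapiens) for cytotoxicity, read by fluorescence, with a stated time of 72 h (a lower number here means a stronger inhibitor, a higher number a weaker inhibitor), compound 1 (`CC(C)c1n[nH]c2c(NCc3ccc(-c4ccccn4)cc3)nc(N3CCCCC3CCO)nc12`) gives 142 nM and holds the lowest of the three numbers so far. Compound 2 (`CC(C)c1n[nH]c2c(NCc3ccc(-c4ccccn4)cc3)nc(NCCN(C)C)nc12`) gives 390 nM and compound 3 (`CC(C)c1n[nH]c2c(NCc3ccc(-c4ccccn4)cc3)nc(N[C@H]3CC[C@H](N)CC3)nc12`) gives 720 nM in the same read-out. Compound 4 (`COc1ccc(CNc2nc(NCc3ccc(-c4ccccn4)cc3)c3[nH]nc(C(C)C)c3n2)cc1`) has not yet been measured. It differs from compound 1 at one place, an aromatic carbon between two ring nitrogen atoms, where (4-methoxybenzyl)amino stands in place of 2-(2-hydroxyethyl)piperidin-1-yl ((4-methoxybenzyl)amino in place of 2-(2-hydroxyethyl)piperidin-1-yl on an aromatic carbon). One six-membered non-aromatic ring with 1 hetero atom thus gives way to one six-membered aromatic ring of carbon only.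

Two measured steps replace the same group at the same place. The first is a 2.7-fold higher number from compound 1 to compound 2 (0.44 log units; beyond the scatter) and the second is a 5.1-fold higher number from compound 1 to compound 3 (0.71 log units; beyond the scatter) and both are modest and point toward a weaker inhibitor. The step of a 1.8-fold higher number from compound 2 to compound 3 (0.27 log units; within the scatter) separates those two replacements. Among the measured compounds shown here, no measured compound carries (4-methoxybenzyl)amino here, so the size of the change remains uncertain. In this assay a move toward a higher number is therefore expected, estimated as a 3.5-fold higher number from compound 1 to compound 4 (0.55 log units; beyond the scatter) and similar in size to those two steps. For compound 4 the estimated value is 500 nM (expected range 150 nM to 1800 nM).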

Compound 4, half-maximal inhibitory concentration: 17400 nM
Estimate against measurement, compound 4: 35-fold (1.54 log units) below; the whole stated range lies below it.
By their numbers in this assay, from the lowest: compound 1; then compounds 2 and 3 (each within the scatter of the next); then compound 4.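

Among these compounds, this position tolerates more than one non-aromatic group, but not every group: in this assay the change to (4-methoxybenzyl)amino gives a 120-fold higher number from compound 1 to compound 4 (2.09 log units; beyond the scatter), far larger than any step among the earlier compounds. The loss is just as clear against the other two compounds, with a 24-fold higher number from compound 3 to compound 4 (1.38 log units; beyond the scatter) and a 45-fold higher number from compound 2 to compound 4 (1.65 log units; beyond the scatter), so it does not depend on which of the three earlier groups serves as the reference. The group that leaves and the group that enters have the same counts of hydrogen-bond donors and acceptors and no net charge, so those counts do not separate compound 1 from compound 4, whereas the six-membered aromatic ring of carbon only does set compound 4 apart from the other three.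

The data shown offer no explanation for this sharp loss. They also leave open whether the aromatic ring, the methoxy group or the benzyl shape matters most, a question that a plain benzylamino group or a cyclohexylmethylamino group on this same aromatic carbon between two ring nitrogen atoms could help to separate.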